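This account rests on a few compounds, and the source may have more. Where it says the series, first, only, none or still open, it means among the compounds named here.

Measured so far in a physicochemical assay for lipophilicity, using the shake flask method, in phosphate buffer, measured as octanol-water partition, with a stated time of 30 min, at pH 7.4; on this read-out higher numbers stand for higher lipophilicity and lower numbers for lower lipophilicity:
compound 1 `COCCC(=O)Nc1cnc(NCc2c(F)ccc3c2CCO3)n2cnnc12` gives 1.4
compound 2 `CN(C)Cc1ccc(C(=O)Nc2cnc(NCc3c(F)ccc4c3CCO4)n3cnnc23)cc1` gives 1.8
compound 3 `CNC(=O)c1ncc(-c2cnc(NCc3c(F)ccc4c3CCO4)c3cn[nH]c(=O)c23)n1C` gives 2.5

Compound 1 stands lowest of the three numbers. Its nearest neighbour is compound 2, which sits a modest step above it: a number 0.40 log units higher from compound 1 to compound 2 (beyond the scatter), beyond the scatter. For the measured compounds named here, compound 3 lies further above compound 1, and no single-point step connects the two, so their values are only compared as they stand.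

Compound 4 `O=C1CCCN1c1cnc(NCc2c(F)ccc3c2CCO3)n2cnnc12` is not yet measured. It differs from compound 1 in one place: 2-oxopyrrolidin-1-yl in place of ((2-methoxyethyl)carbonyl)amino on an aromatic carbon.

Going by the values given here, only one measured step is available, a number 0.40 log units higher from compound 1 to compound 2 (beyond the scatter), and it concerns a different exchange at the same carbonyl carbon rather than the change that leads to compound 4, so it bears on the question only loosely. It does show that a change of the acyl group on this core can move the read-out by a modest amount. For compound 4 a shift of similar or smaller size is expected, in the upward direction, though a result within the scatter of compound 1 cannot be ruled out.

Compound 4 is therefore estimated at 1.7 in this assay, within 1.3 to 2.2. The expected step is a number 0.30 log units higher from compound 1 to compound 4 (within the scatter).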

Compound 4, distribution coefficient: 1.3
Compound 4: middle estimate off by 0.40 log units, on the high side; the range from low to high includes it.
By their numbers in this assay, from the lowest: compounds 4 and 1 (each within the scatter of the next); then compound 2; then compound 3.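

In this assay, exchanging ((2-methoxyethyl)carbonyl)amino for 2-oxopyrrolidin-1-yl on this aromatic carbon gives a number 0.10 log units lower from compound 1 to compound 4 (within the scatter), so the read-out does not separate these two compounds. The entering group has 0 hydrogen-bond donors against 1 in the leaving group, as well as a five-membered non-aromatic ring, yet this exchange stays within the scatter, whereas the earlier exchange on the carbonyl carbon, a number 0.40 log units higher from compound 1 to compound 2 (beyond the scatter), lay beyond it. No measurement at hand accounts for this outcome.

Still open, from the compounds shown here alone, is whether a primary amine, a carboxylic acid or a longer alkyl chain on this aromatic carbon would also stay within the scatter of compound 1. A six-membered lactam in place of 2-oxopyrrolidin-1-yl is equally unresolved, so it remains unknown how far this result extends beyond the single ring shown.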